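A few compounds are considered here, and "the series" means these few. Any claim that something is new, unique, unknown or untested is made for them only; others in the source may bear on it.

Measured so far, each in a toxicity assay on the whole organism (P388 cells) for cytotoxicity, with Mus musculus as the target, with a stated time of 9 days, at a dose of 20 mg/kg by the intraperitoneal route; on this read-out lower numbers stand for a stronger effect and higher numbers for a weaker effect at the one dose given:

Compound 1 `CN(C)/N=N\c1ccnc2c(Br)cccc12` gives 16%.
Compound 2 `CN(C)/N=N\c1ccnc2ccc(Br)cc12` gives 18%.

For the measured compounds named here, of these two numbers, the one for compound 2 is the higher, but its nearest neighbour is compound 1, whose number sits within the scatter of repeated measurements, so the two compounds cannot be told apart on this read-out and neither can be called the stronger.

Compound 3 `CN(C)/N=N\c1ccnc2ccc(Cl)cc12` has not been measured. It differs from compound 2 in one place: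

chloro in place of bromo on an aromatic carbon

A single halogen is thus swapped for another at the same position on the shared core, with nothing else changed. Going by the values given here, no step between two measured compounds speaks to this kind of swap here. The two measured compounds show that the core with a bromo at either of two positions lands at a similar level, and the account rests on that alone. The author therefore expects no step beyond the scatter in this assay for this change, with the estimated step of a number 1 percentage points higher from compound 2 to compound 3 (within the scatter).

For compound 3 the estimate in this assay is 19%, with a range from 8% to 32%.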

Compound 3, a percentage reported as activity, at one dose (the size of the read-out at that dose, not a potency): 0.8%
Estimate against measurement, compound 3: 18.2 percentage points above, outside the stated range (below it).
By their numbers in this assay, from the lowest: compound 3; then compounds 1 and 2 (each within the scatter of the next).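

In this assay, exchanging one halogen for another on this aromatic carbon gives a number 17.2 percentage points lower from compound 2 to compound 3 (beyond the scatter), so on this read-out the change moves towards the stronger effect. The earlier compounds shown here carried only bromo and could not show this, whereas the new result shows that the read-out responds to which halogen sits at this place, even though the swap replaces one heavy atom with another and leaves the counts of hydrogen-bond donors and acceptors, the net charge and the ring count unchanged. No measurement shown here accounts for the size of this step, so its origin remains unknown.

The compounds shown leave open what a fluoro, a methoxy or an amine on this same carbon would give, and therefore whether the step is peculiar to chloro or part of a wider trend across substituents. They also leave open whether chloro in place of the bromo of compound 1 would produce a similar step, and, with a single dose in this assay, whether the swap would give a stronger or weaker effect at any other dose.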